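The source may report more compounds than this note shows. Statements on the series, on what has been measured and on what is new or still open speak of the compounds shown alone.

Values in a functional assay on U-937 cells (Homo sapiens) for cytotoxicity, read by MTT assay, with a stated time of 48 h; on this read-out higher numbers stand for weaker inhibition and lower numbers for stronger inhibition:
Compound 1 `Oc1ccccc1Nc1nc(-c2cccc(F)c2)nc2ccc(F)cc12`: 46300 nM
Compound 2 `Nc1ccccc1Nc1nc(-c2cccc(F)c2)nc2ccc(F)cc12`: 47300 nM
Compound 3 `Cc1ccc(Nc2nc(-c3cccc(F)c3)nc3ccc(F)cc23)cc1`: > 50000 nM (a limit of the assay, not a number)

Compound 3 has no exact number in this assay, only a limit: the limit of > 50000 nM in this assay, at which 1 of the 3 values shown sits. Compound 4 `Cc1cccc(Nc2nc(-c3cccc(F)c3)nc3ccc(F)cc23)c1` has the same atoms as compound 3, joined differently, with 3-methylphenyl in place of 4-methylphenyl on a nitrogen on an aromatic ring.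

For the measured compounds named here, no measured step makes this exact exchange, so the nearest evidence comes from other changes to the group on that nitrogen. Putting 4-methylphenyl in place of 2-hydroxyphenyl gave an at least 1.0-fold higher number from compound 1 to compound 3 (0.03 log units; that floor lies within the scatter). Putting 4-methylphenyl in place of 2-aminophenyl gave an at least 1.0-fold higher number from compound 2 to compound 3 (0.02 log units; that floor lies within the scatter). On these data alone, both are only floors, so the true sizes remain open, but neither shows a change beyond the scatter. Amino in place of hydroxy gave a 1.0-fold higher number from compound 1 to compound 2 (0.01 log units; within the scatter), also within the scatter.

On this basis, no step beyond the scatter is expected in this assay, and the result may again be only a limit. The expected step is a number no higher from compound 3 to compound 4 (the limit leaves the size open). For compound 4 the estimate is 50000 nM, with an expected range from 30000 nM to 100000 nM.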

Compound 4, half-maximal inhibitory concentration: > 50000 nM
Compound 4 ended at the assay's limit; the forecaster's own chance of this, stated with the estimate: 60%; the middle value lies on the limit itself.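

Moving the methyl group from 4-methylphenyl to 3-methylphenyl leaves compound 4, like compound 3, with only a limit of the assay and no exact number in this assay, so the step between them cannot be read. Set against the two compounds with exact numbers, the 3-methylphenyl group gives an at least 1.0-fold higher number from compound 2 to compound 4 (0.02 log units; that floor lies within the scatter) and an at least 1.0-fold higher number from compound 1 to compound 4 (0.03 log units; that floor lies within the scatter), and these floors show no change beyond the scatter, although the true sizes remain open. The limit now applies to more than one compound in this small set, so this end of the assay's range hides any difference among such compounds: the limit of > 50000 nM in this assay, at which 2 of the 4 values shown sit.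

On these data alone, neither compound 3 nor compound 4 has an exact number, so it stays open whether moving the methyl group changes the result at all. As far as these compounds go, it also stays open how this assay would respond if a carboxylic acid, an amine or a longer chain stood in place of the methyl group on the phenyl ring.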